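A few compounds are considered here, and "the series" means these few. Any claim that something is new, unique, unknown or untested is made for them only; others in the source may bear on it.

In a functional assay on cells for agonist activity at Free fatty acid receptor 1 (Rattus norvegicus), read by FLIPR and calcium flux (a higher number here means that more compound is needed for the effect, a lower number that less compound is needed), two compounds of this series have been measured. Compound 1 `CC#C[C@@H](Cc1nnn[nH]1)c1ccc(OCc2ccc3sc(C#N)c(-c4ccccc4C)c3c2)cc1` gives 19 nM in this assay, and compound 2 `CC#C[C@@H](Cc1nnn[nH]1)c1ccc(OCc2ccc3sc(I)c(-c4ccccc4C)c3c2)cc1` gives 33 nM. Among the compounds with values here, the only measured step, a 1.7-fold higher number from compound 1 to compound 2 (0.24 log units; within the scatter), replaces a cyano with an iodo on an aromatic carbon, so the two halogen-like substituents at that carbon are indistinguishable within the scatter. Within the data shown here, compound 2 stands at the higher of the two numbers, with compound 1 its only neighbour.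

Compound 3 `CC#C[C@@H](Cc1nnn[nH]1)c1ccc(OCc2ccc3sc(C)c(-c4ccccc4C)c3c2)cc1` differs from compound 2 in a single place: methyl in place of iodo on an aromatic carbon. Among the measured compounds shown here, no measured step exchanges iodo for methyl, so the one step that bears on it is a 1.7-fold higher number from compound 1 to compound 2 (0.24 log units; within the scatter), which shows that swapping the substituent at this aromatic carbon left the number essentially unchanged. On that basis compound 3 is expected to show a 1.1-fold higher number from compound 2 to compound 3 (0.03 log units; within the scatter) in this assay, a step not beyond the scatter. The estimate for compound 3 is 35 nM, with a range from 12 nM to 100 nM.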

Compound 3, half-maximal effective concentration: 10 nM
Estimate against measurement, compound 3: 3.5-fold (0.54 log units) above; the whole stated range lies above it.
By their numbers in this assay, from the lowest: compounds 3, 1 and 2 (each within the scatter of the next, the first and the last beyond it).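

At the aromatic carbon next to the ring sulfur, the choice of substituent does register in this assay: methyl in place of iodo gives a 3.3-fold lower number from compound 2 to compound 3 (0.52 log units; beyond the scatter) as a modest step, the first one here beyond the scatter. Methyl in place of cyano gives a 1.9-fold lower number from compound 1 to compound 3 (0.28 log units; within the scatter) and stays within it, so compound 1 and compound 3 cannot be told apart, and only the pair compound 2 and compound 3 is separated at this position. Nothing available explains that separation.

From the compounds shown here alone, it remains open whether an amine, a carboxylic acid or a longer chain at this carbon would stay level with compound 3 or move away from it. Going by these compounds, it also remains open whether the methyl and iodo difference would persist if the 2-methylphenyl group were replaced by another group.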